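Removing the Fluoro Group from Compound 3

This account rests on a few compounds, and the source may have more. Where it says the series, first, only, none or still open, it means among the compounds named here.

Measured in a functional assay on HepG2 cells (Homo sapiens) for antiproliferative activity, read by MTT assay, with a stated time of 48 h; on this read-out higher numbers stand for weaker inhibition and lower numbers for stronger inhibition:
Compound 1 `CCCCOc1ccc(C(=O)/C=C/c2c(/C=C/c3ccc(OC)cc3)cc(OC)cc2OC)cc1`: 12.9 ug/mL
Compound 2 `COc1ccc(/C=C/c2cc(OC)cc(OC)c2/C=C/C(=O)c2cccc(Br)c2)cc1`: 13 ug/mL
Compound 3 `COc1ccc(/C=C/c2cc(OC)cc(OC)c2/C=C/C(=O)c2ccc(F)cc2)cc1`: 12.2 ug/mL

Compound 3 gives 12.2 ug/mL, which lies within the scatter of both other compounds, so the three cannot be ranked. Compound 4 `COc1ccc(/C=C/c2cc(OC)cc(OC)c2/C=C/C(=O)c2ccccc2)cc1` has not yet been measured. It differs from compound 3 by a single change: hydrogen in place of fluoro on an aromatic carbon. This places hydrogen in place of fluoro on an aromatic carbon, para to a large group.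

The closest evidence comes from the three measured steps, which all alter the group on the carbonyl carbon. They are a 1.1-fold lower number from compound 1 to compound 3 (0.02 log units; within the scatter), a 1.1-fold lower number from compound 2 to compound 3 (0.03 log units; within the scatter) and a 1.0-fold higher number from compound 1 to compound 2 (0.00 log units; within the scatter). Going by the values given here, none goes beyond the scatter, although no measured step tests this exact replacement. No shift beyond the scatter, in either direction, is therefore expected in this assay. The expected change is a 1.0-fold higher number from compound 3 to compound 4 (0.01 log units; within the scatter). The estimate for compound 4 is 12.5 ug/mL, with an expected range of 7.5 ug/mL to 20 ug/mL.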

Compound 4, half-maximal inhibitory concentration: 6.8 ug/mL
Compound 4: middle estimate off by 1.8-fold (0.26 log units), on the high side; the measured number lies below the stated range.
By their numbers in this assay, from the lowest: compounds 4, 3, 1 and 2 (each within the scatter of the next).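

In this assay, going by these compounds alone, compound 4 offers the first look at the ring on the carbonyl with no added group, and taking away the fluoro gives a 1.8-fold lower number from compound 3 to compound 4 (0.25 log units; within the scatter) at this place. Within the data shown here, the other two comparisons read the same way, with a 1.9-fold lower number from compound 2 to compound 4 (0.28 log units; within the scatter) on losing the bromo and a 1.9-fold lower number from compound 1 to compound 4 (0.28 log units; within the scatter) on losing the butoxy, so hydrogen, fluoro, bromo and butoxy on this ring cannot be told apart here, although each of these steps is larger than any among the earlier compounds. No measurement shown bears on the reason for these small differences.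

On these data alone, whether an amine or a carboxylic acid on this ring would move the number beyond the scatter remains open. So does the effect of a chain longer than butoxy.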